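The source may report more compounds than this note shows. Statements on the series, on what has been measured and on what is new or still open speak of the compounds shown alone.

In a functional assay on MDA-MB-231 cells (Homo sapiens) for antiproliferative activity, read by MTT assay, with a stated time of 6 days (on this read-out higher numbers stand for weaker inhibition and lower numbers for stronger inhibition), compound 2 (`O=C1C=C[C@@H](OCc2ccccc2)[C@@H]([C@@H](COC(=O)/C=C/c2ccccc2)OCc2ccccc2)O1`) gives 4970 nM. That lies within the scatter of compound 3 (`CC(=O)OC[C@@H](OC(C)=O)[C@H]1OC(=O)C=C[C@H]1OC(C)=O`), at 7480 nM, and is a higher number than compound 1 (`CC(=O)O[C@@H]1C=CC(=O)O[C@@H]1[C@@H](COC(=O)c1ccc(Cl)cc1)OC(C)=O`), at 1850 nM. Compound 4 (`O=C1C=C[C@@H](OCc2ccccc2)[C@@H]([C@@H](CO)OCc2ccccc2)O1`) carries hydrogen in place of (2-phenylethenyl)carbonyl on an oxygen on a saturated carbon. For the measured compounds named here, one measured step bears on this, a 4.0-fold higher number from compound 1 to compound 3 (0.61 log units; beyond the scatter), with methyl in place of 4-chlorophenyl on a carbonyl carbon. Going by the values given here, that modest step also takes away an aromatic ring, but no measured compound carries the free hydroxy group. A modest move to a higher number is therefore expected in this assay. The estimated step is a 1.8-fold higher number from compound 2 to compound 4 (0.26 log units; within the scatter). For compound 4 the estimated value is 9000 nM, with an expected range of 3000 nM to 25000 nM.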

Compound 4, half-maximal inhibitory concentration: 4790 nM
Estimate against measurement, compound 4: 1.9-fold (0.27 log units) above, within the range that was stated.
By their numbers in this assay, from the lowest: compound 1; then compounds 4, 2 and 3 (each within the scatter of the next).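

In this assay, hydrogen in place of (2-phenylethenyl)carbonyl gives a 1.0-fold lower number from compound 2 to compound 4 (0.02 log units; within the scatter), so on this oxygen the free hydroxy and the full acyl group cannot be told apart. For the compounds shown here, the one earlier step at this oxygen, a 4.0-fold higher number from compound 1 to compound 3 (0.61 log units; beyond the scatter), lay beyond the scatter, but it exchanged one acyl group for another on a differently substituted core. No evidence on the cause of this result is available.

Open, as far as these compounds go, is whether an amine or a carboxylic acid in place of the hydroxymethyl would hold the number, and whether removing the acyl group from compound 1 would also leave its number unmoved.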